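The source may hold more compounds than are shown below. What is called first, only, known or untested is meant among the compounds shown, and "the series" means these compounds.

Working notes on the series. Compound 1 `COc1ccc(/C=C\C(=O)O)c(OCc2cn(-c3ccccc3F)nn2)c1CC=C(C)C` and compound 2 `COc1ccc(/C=C\C(=O)O)c(OCc2cn(-c3cccnc3Cl)nn2)c1CC=C(C)C` share one core and differ only in the aryl group on an aromatic nitrogen of the five-membered ring. In a functional assay on A-431 cells (Homo sapiens) for cytotoxicity, read by MTT assay, with a stated time of 24 h (a lower number here means a stronger inhibitor, a higher number a weaker inhibitor), compound 1 gives 12400 nM, and compound 2 gives 32600 nM. Among the compounds with values here, the change a 2.6-fold higher number from compound 1 to compound 2 (0.42 log units; beyond the scatter) is the only measured step so far. On these numbers compound 2 has the highest value of the two, with compound 1 as its nearest neighbour at a lower number.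

Compound 3 `COc1ccc(/C=C\C(=O)O)c(OCc2cn(-c3ccccc3C#N)nn2)c1CC=C(C)C` is the next point on the same position: 2-cyanophenyl in place of 2-chloropyridin-3-yl on an aromatic nitrogen. Within the data shown here, the one measured step concerns the same position and was modest, so a step of similar size is expected, most likely back toward the lower number of compound 1, though no step with a nitrile on this ring exists yet. The expectation for compound 3 in this assay is 15000 nM, with a range of 6000 nM to 40000 nM, which means an expected 2.2-fold lower number from compound 2 to compound 3 (0.34 log units; beyond the scatter).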

Compound 3, half-maximal inhibitory concentration: 10300 nM
The estimate for compound 3 lay 1.5-fold (0.16 log units) above the measured number; the range from low to high includes it.
By their numbers in this assay, from the lowest: compounds 3 and 1 (each within the scatter of the next); then compound 2.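

In this assay the 2-cyanophenyl group brings a 3.2-fold lower number from compound 2 to compound 3 (0.50 log units; beyond the scatter) and so shows that the gap to 2-chloropyridin-3-yl is not confined to 2-fluorophenyl. Among the rings of carbon only, cyano in place of fluoro gives a 1.2-fold lower number from compound 1 to compound 3 (0.08 log units; within the scatter) and leaves the two substituents unresolved here, so compound 2 alone stands apart from compounds 1 and 3. No measurement at hand gives a reason for this difference.

Compound 2 differs from compounds 1 and 3 in both its ring nitrogen and its chloro group, so the contribution of each remains unresolved. A 2-chlorophenyl group would help separate the two, while an amine on the same ring would test whether this position tolerates a group unlike fluoro or cyano.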